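From ethylsulfanyl to ethyl on the shared core

A few compounds are considered here, and "the series" means these few. Any claim that something is new, unique, unknown or untested is made for them only; others in the source may bear on it.

- compound 1 `N=c1sc2ccccc2n1CCSS(=O)(=O)O`: "nd(insoluble)" (no result reported)
- compound 2 `CCSc1nn(CCSS(=O)(=O)O)c(=N)s1`: 8320 nM

In a functional assay (a higher number here means a weaker inhibitor, a lower number a stronger inhibitor), compound 2 stands at 8320 nM. For the measured compounds named here, this is the only number available, since compound 1 gave no numerical result, so compound 2 cannot yet be ranked against anything.

Compound 3 `CCc1nn(CCSS(=O)(=O)O)c(=N)s1` has not been measured. It keeps the rest of compound 2 and carries ethyl in place of ethylsulfanyl on an aromatic carbon. Going by the values given here, no measured pair shows what a change at this place does in this assay, so neither direction can be favoured with confidence. The expected step, a 1.0-fold higher number from compound 2 to compound 3 (0.01 log units; within the scatter), stays within the usual scatter. For compound 3 the estimate is 8500 nM, with an expected range from 2500 nM to 30000 nM.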

Compound 3, half-maximal inhibitory concentration: 51900 nM
Compound 3: the middle estimate sits 6.1-fold (0.79 log units) below what was measured; measured number outside the range, above it.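

In this assay, for the compounds shown here, the swap of ethylsulfanyl for ethyl on this aromatic carbon gives a 6.2-fold higher number from compound 2 to compound 3 (0.80 log units; beyond the scatter), the first step that can be read at all, and it shows that the group at this position matters to the read-out. Of this pair, compound 2, with ethylsulfanyl, is the stronger inhibitor, so the sulfur-bearing group is the better of the two tested here. No measurement is available that would explain this step.

The compounds shown leave open whether other groups at this carbon, such as methoxy, an amine or a longer alkylsulfanyl chain, would match or improve on ethylsulfanyl. They also leave open how the core of compound 1 compares, since that compound gives no number to set against the others.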